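Ethyl-oxazolylamino analogue in the thiazolidinedione series

The source may report more compounds than this note shows. Statements on the series, on what has been measured and on what is new or still open speak of the compounds shown alone.

Measured so far:
compound 1 `Cn1c(/C=C2\SC(=O)N(CC(=O)Nc3cc(C(C)(C)C)on3)C2=O)nc2ccccc21` — > 50000 nM
compound 2 `CCn1c(/C=C2\SC(=O)N(CC(=O)N3CCCCC3)C2=O)nc2ccccc21` — > 50000 nM
compound 3 `Cn1c(/C=C2\SC(=O)N(CC(=O)N3CCCCC3)C2=O)nc2ccccc21` — > 50000 nM

In a functional assay on PC-3 cells (Homo sapiens) for inhibition, read by MTT assay, with a stated time of 48 h (on this read-out lower numbers stand for stronger inhibition and higher numbers for weaker inhibition), compound 2 gives only a limit, > 50000 nM. Compound 1 likewise gives only a limit, > 50000 nM. Compound 3 too returns only a limit, > 50000 nM. All three sit at the limit of > 50000 nM in this assay, at which 3 of the 3 values shown sit. Compound 4 `CCn1c(/C=C2\SC(=O)N(CC(=O)Nc3cc(C(C)(C)C)on3)C2=O)nc2ccccc21` is not yet measured; it differs from compound 2 by (5-(tert-butyl)-1,2-oxazol-3-yl)amino in place of piperidin-1-yl on a carbonyl carbon. The same exchange was made within the methyl pair, but a step that the two limits leave unreadable from compound 1 to compound 3 cannot be read, and the ethyl-for-methyl step that the two limits leave unreadable from compound 2 to compound 3 is equally unreadable. Going by the values given here, nothing among the measured compounds points to a gain in this assay, so compound 4 is expected to stay at the limit as well, a step that the limit leaves unreadable from compound 2 to compound 4. The estimate for compound 4 is 60000 nM, with a range from 20000 nM to 200000 nM.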

Compound 4, half-maximal inhibitory concentration: > 50000 nM
Compound 4 ended at the assay's limit (the forecaster's own chance of this, stated with the estimate: 85%); the middle value lies beyond the limit too.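

No new step can be read for compound 4 against compound 1 or compound 2, because all values are limits, not numbers: the limit of > 50000 nM in this assay, at which 4 of the 4 values shown sit.

The compounds shown leave open how these four differ in inhibition and which change to the shared core would give a readable value.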